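A few compounds are considered here, and "the series" means these few. Any claim that something is new, unique, unknown or untested is made for them only; others in the source may bear on it.

Measured so far:
compound 1, `O[C@H](COCCOC[C@@H](O)Cc1cn(-c2cccs2)nn1)Cc1ccc(-c2ccccc2)cc1`: 33400 nM
compound 2, `COC1=C(C)C(=O)C(CCCCCCCCCCn2cc(C[C@H](O)COCCOC[C@@H](O)Cc3ccc(-c4ccccc4)cc3)nn2)=C(C)C1=O`: 505 nM

Both numbers come from a functional assay on SGC-7901 cells (Homo sapiens) for inhibition, read by MTT assay, with a stated time of 72 h; on this read-out lower numbers stand for stronger inhibition of growth and higher numbers for weaker inhibition of growth. Among the measured compounds shown here, compound 1 stands at the highest of the two numbers; the only neighbour is compound 2, and the gap between compound 1 and compound 2 lies beyond the scatter. For the measured compounds named here, compound 2 differs from compound 1 in more than one place, so its number shows only that the shared core can reach far lower values when the group on the aromatic nitrogen is changed; it says nothing of any single change.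

Compound 3, `O[C@H](COCCOC[C@@H](O)Cc1cn(Cc2ccc(C(F)(F)F)cc2)nn1)Cc1ccc(-c2ccccc2)cc1`, is not yet measured. It differs from compound 1 in one place: 4-(trifluoromethyl)benzyl in place of thiophen-2-yl on an aromatic nitrogen. Going by the values given here, no measured pair carries this change, so nothing beyond the two numbers above supports an expectation. The group that enters is larger than the group that leaves, and compound 2 shows that a larger group at this position can go with a lower number; from this a modest step downward, beyond the scatter but far smaller than the gap to compound 2, is expected, as the estimated step of a 2.8-fold lower number from compound 1 to compound 3 (0.44 log units; beyond the scatter) in this assay states. For compound 3 the expected value is 12000 nM, with a range from 4000 nM to 36000 nM.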

Compound 3, concentration for 50% growth inhibition: 8700 nM
Beside the measured number, compound 3's estimate is 1.4-fold (0.14 log units) above it; the measured number falls inside the stated range.
By their numbers in this assay, from the lowest: compound 2; then compound 3; then compound 1.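

In this assay, among the compounds shown here, the exchange of thiophen-2-yl for 4-(trifluoromethyl)benzyl on the aromatic nitrogen gives a 3.8-fold lower number from compound 1 to compound 3 (0.58 log units; beyond the scatter), the first step that can be read for a single change at this position, which the comparison with compound 2 could not provide. The entering group has 11 heavy atoms against 5 and brings a six-membered aromatic ring of carbon only in place of a five-membered aromatic ring with 1 hetero atom, but this single pair cannot separate the contributions of ring type, the benzyl link and the trifluoromethyl group. No measurement on these compounds offers an explanation for the step.

On these data alone, it remains open whether plain benzyl on the same nitrogen would give a step of similar size, which would allow the trifluoromethyl group to be judged on its own. Also open, as far as these compounds go, is whether a longer alkyl chain, or one ending in an amine or a carboxylic acid, would move the number further at this position.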